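Methoxy addition on the styryl lactone series

This account rests on a few compounds, and the source may have more. Where it says the series, first, only, none or still open, it means among the compounds named here.

Measured so far:
compound 1 `COc1ccc(-c2cc(=O)cco2)cc1` — > 1230 uM
compound 2 `COc1ccc(/C=C/C2CC=CC(=O)O2)c(OC)c1` — 6 uM

Compound 1 is recorded in a functional assay on NCI-H460 cells (Homo sapiens) for inhibition, read by sulforhodamine B assay, with a stated time of 48 h (on this read-out higher numbers stand for weaker inhibition of growth and lower numbers for stronger inhibition of growth), only as a limit: compound 1 gives > 1230 uM. In this assay, among the measured compounds shown here, compound 2 gives 6 uM, the only numerical value in the set. Compound 3 `COc1cc(OC)c(OC)cc1/C=C/C1CC=CC(=O)O1` is still to be measured. It differs from compound 2 by methoxy in place of hydrogen on an aromatic carbon. For the measured compounds named here, no measured step between compounds is available, so the expected change in this assay is small, not beyond the scatter, in either direction. Compound 3 is estimated at 5 uM, in the range 1.5 uM to 20 uM. The expected step of a 1.2-fold lower number from compound 2 to compound 3 (0.08 log units; within the scatter) is minor.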

Compound 3, concentration for growth inhibition (reported as GI): 9.8 uM
Compound 3: the middle estimate sits 2.0-fold (0.29 log units) below what was measured; measured number inside the range.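

In this assay methoxy in place of hydrogen on this aromatic carbon, ortho to one methoxy group and para to another, gives a 1.6-fold higher number from compound 2 to compound 3 (0.21 log units; within the scatter) and so leaves the two compounds within the scatter of each other. This position therefore tolerates methoxy on this read-out. Nothing shown bears on the reason for this step.

From the compounds shown here alone, whether a different group on this carbon, such as an amine, a carboxylic acid or a longer alkoxy chain, would give a step beyond the scatter remains open.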